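A few compounds are considered here, and "the series" means these few. Any claim that something is new, unique, unknown or untested is made for them only; others in the source may bear on it.

In a functional assay on MGC-803 cells (Homo sapiens) for cytotoxicity, read by MTT assay, with a stated time of 72 h (a lower number here means a stronger inhibitor, a higher number a weaker inhibitor), compound 1 `C=C1C(=O)[C@@]23C(=O)OC[C@]4(C(=O)CCC(C)(C)[C@H]4C=O)[C@@H]2CC[C@@H]1[C@H]3OC(=O)c1ccc(C)cc1` gives 2240 nM and compound 2 `C=C1C(=O)[C@@]23C(=O)OC[C@]4(C(=O)CCC(C)(C)[C@H]4C=O)[C@@H]2CC[C@@H]1[C@H]3OC(=O)c1ccc(Cl)cc1` gives 3120 nM. These two numbers lie within the usual scatter of each other, so the data do not separate compound 2 from compound 1.

The next structure is compound 3 `C=C1C(=O)[C@@]23C(=O)OC[C@]4(C(=O)CCC(C)(C)[C@H]4C=O)[C@@H]2CC[C@@H]1[C@H]3OC(=O)c1ccccc1Cl`, which carries 2-chlorophenyl in place of 4-chlorophenyl on a carbonyl carbon. The atoms stay the same and only the way they are joined differs. Within the data shown here, no measured pair shows what this particular change does, so the evidence is indirect.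

Among the measured compounds shown here, the one measured step, a 1.4-fold higher number from compound 1 to compound 2 (0.14 log units; within the scatter), replaces methyl with chloro on an aromatic carbon of the same group and stays within the scatter. On that slim basis, no shift beyond the scatter is expected in this assay, and no direction can be favoured with confidence.

The expected change is a 1.0-fold lower number from compound 2 to compound 3 (0.02 log units; within the scatter), a small step that could go either way. For compound 3 the estimated value is 3000 nM, with an expected range of 1200 nM to 7500 nM.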

Compound 3, half-maximal inhibitory concentration: 2660 nM
Compound 3: middle estimate off by 1.1-fold (0.05 log units), on the high side; the range from low to high includes it.
By their numbers in this assay, from the lowest: compounds 1, 3 and 2 (each within the scatter of the next).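

The earlier step changed which group sat on the aromatic ring, whereas this one keeps the same atoms and changes only how they are joined. Putting 2-chlorophenyl in place of 4-chlorophenyl on the carbonyl carbon gives a 1.2-fold lower number from compound 2 to compound 3 (0.07 log units; within the scatter) in this assay, and putting 2-chlorophenyl in place of 4-methylphenyl gives a 1.2-fold higher number from compound 1 to compound 3 (0.07 log units; within the scatter), so all three groups tried at this position now lie within the scatter of one another. No separate measurement bears on this result, so what lies behind it remains unexplained.

From the compounds shown here alone, all three compounds carry a substituted phenyl group on this carbonyl carbon, so it remains open whether a different kind of group there, such as a phenyl ring bearing an amine or carboxylic acid, or a longer carbon chain in place of the ring, would move the number beyond the scatter. The shared core is identical in all three compounds, so they also leave open how much of the cytotoxicity depends on the core rather than on this ester group.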